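This account rests on a few compounds, and the source may have more. Where it says the series, first, only, none or still open, it means among the compounds named here.

Three measured compounds share one core and differ only in the group on an aromatic nitrogen of the fused ring. Compound 1 `CC(C)c1onc(-c2c(Cl)cccc2Cl)c1COc1ccc(-c2nc3ccc(C(=O)O)cc3n2C2CC2)cc1` carries a cyclopropyl there, and in an assay on Huh-7 cells for agonist activity at Bile acid receptor (Homo sapiens), read by a luciferase reporter (a lower number here means that less compound is needed, a higher number that more compound is needed for the effect), compound 1 gives 16.5 nM. Compound 2 `CC(C)c1onc(-c2c(Cl)cccc2Cl)c1COc1ccc(-c2nc3ccc(C(=O)O)cc3n2CC2CC2)cc1` carries a cyclopropylmethyl, and in this assay compound 2 gives 19.4 nM; the step of a 1.2-fold higher number from compound 1 to compound 2 (0.07 log units; within the scatter) lies within the scatter. Compound 3 `CC(C)c1onc(-c2c(Cl)cccc2Cl)c1COc1ccc(-c2nc3ccc(C(=O)O)cc3n2C(C)C)cc1` carries an isopropyl, and in this assay compound 3 gives 3.39 nM, the lowest of the three numbers, reached by the steps of a 4.9-fold lower number from compound 1 to compound 3 (0.69 log units; beyond the scatter) and a 5.7-fold lower number from compound 2 to compound 3 (0.76 log units; beyond the scatter).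

Compound 4 `CC(C)c1onc(-c2c(Cl)cccc2Cl)c1COc1ccc(-c2nc3ccc(C(=O)O)cc3n2C2CCCCC2)cc1` takes the step (cyclohexyl in place of isopropyl on an aromatic nitrogen). Within the data shown here, no measured step exchanges an isopropyl for a six-membered ring, so the nearest guide is that both groups containing a ring, in compound 1 and compound 2, gave higher numbers in this assay than the isopropyl of compound 3. From that, a modest rise for compound 4 is expected rather than a further fall, though the size is uncertain. The expected step is a 2.9-fold higher number from compound 3 to compound 4 (0.47 log units; beyond the scatter). Compound 4 is therefore estimated at 10 nM in this assay, with a range from 3 nM to 40 nM.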

Compound 4, half-maximal effective concentration: 4.21 nM
For compound 4 the middle estimate is 2.4-fold (0.38 log units) above the measured one; the measured number falls inside the stated range.
By their numbers in this assay, from the lowest: compounds 3 and 4 (each within the scatter of the next); then compounds 1 and 2 (each within the scatter of the next).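

In this assay the step of a 1.2-fold higher number from compound 3 to compound 4 (0.09 log units; within the scatter) shows that this position accepts cyclohexyl, with 6 heavy atoms where isopropyl has 3, without a change beyond the scatter. A ring on the aromatic nitrogen therefore does not by itself go with a higher number, as the two ring-bearing groups seen earlier suggested: the other new steps are a 4.6-fold lower number from compound 2 to compound 4 (0.66 log units; beyond the scatter) and a 3.9-fold lower number from compound 1 to compound 4 (0.59 log units; beyond the scatter) and they place compound 4 with compound 3, apart from the cyclopropyl and cyclopropylmethyl compounds. Heavy atom count does not order these four groups either, and nothing available explains why cyclopropyl and cyclopropylmethyl stand apart from isopropyl and cyclohexyl.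

The compounds shown leave open where a cyclobutyl or cyclopentyl ring would fall, which would tell whether the higher number of cyclopropyl is a lone case among rings joined directly to this nitrogen. They also leave open what an ethyl, a longer chain or a cyclohexyl ring carrying an amine would give at this position.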